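Swapping methoxy for dimethylamino on a cyclohexanone core

This account rests on a few compounds, and the source may have more. Where it says the series, first, only, none or still open, it means among the compounds named here.

Measured compounds:
compound 1 `COc1ccc(/C=C2\CCC/C(=C\c3ccc([N+](=O)[O-])cc3)C2=O)cc1` gives 240000 nM
compound 2 `O=C1/C(=C/c2ccc(F)cc2)CCC/C1=C\c1cccc([N+](=O)[O-])c1` gives 16300 nM
compound 3 `COc1cc(/C=C2\CCC/C(=C\c3cccc([N+](=O)[O-])c3)C2=O)cc(OC)c1OC` gives 42200 nM

In a functional assay on L1210 cells (Mus musculus) for cytotoxicity, with a stated time of 48 h (a higher number here means a weaker inhibitor, a lower number a stronger inhibitor), compound 1 gives the highest of the three numbers. Its nearest neighbour is compound 3, whose number is lower by a gap beyond the scatter, and compound 2 lies further still below it. No pair among these three differs in only one place, so no single step between measured compounds can be read from them.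

Compound 4 `CN(C)c1ccc(/C=C2\CCC/C(=C\c3ccc([N+](=O)[O-])cc3)C2=O)cc1` has not yet been measured in this assay. It differs from compound 1 in one place: dimethylamino in place of methoxy on an aromatic carbon. For the measured compounds named here, nothing among the measured compounds shows what this exchange does on this core, so the direction of the step is open. The expectation is a step of moderate size, more likely towards a lower number, and the expected step from compound 1 to compound 4 in this assay is a 2.4-fold lower number from compound 1 to compound 4 (0.38 log units; beyond the scatter). Compound 4 is therefore estimated at 100000 nM, with a range from 20000 nM to 400000 nM.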

Compound 4, half-maximal inhibitory concentration: > 500000 nM
Compound 4: a limit, no number (the forecaster's own chance of this, stated with the estimate: 10%); at least 5.0-fold (0.69 log units) between middle value and limit.
By their numbers in this assay, from the lowest: compound 2; then compound 3; then compound 1. At a limit, above all of these: compound 4.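

Dimethylamino in place of methoxy on an aromatic carbon, para to a large group, gives an at least 2.0-fold higher number from compound 1 to compound 4 (0.31 log units; beyond the scatter) in this assay; this is the first single change that can be read on the shared core, and it runs towards weaker inhibition, starting from a compound that already had the highest number of the first three. Compound 4 gives > 500000 nM, and this is a limit, not a number. The size of the step therefore has only a lower bound: the limit of > 500000 nM in this assay, at which 1 of the 4 values shown sits.

The compounds shown leave open whether this exchange runs the same way with the other aromatic substitution seen in compounds 2 and 3, since only one pair can be read. They also leave open what a primary amine, a hydroxyl group or a longer chain such as ethoxy would give at this position.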